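The source may report more compounds than this note shows. Statements on the series, on what has been measured and on what is new or still open speak of the compounds shown alone.

Measured so far:
- compound 1 `NC1=NC2(CCSCC2)N(OCCCOc2ccc(Br)cc2)C(N)=N1`: 440 nM
- compound 2 `NC1=NC2(CCSCC2)N(OCCCOc2cccc(Br)c2)C(N)=N1`: 60 nM

In a functional assay on MDA-MB-231 cells (Homo sapiens) for antiproliferative activity, read by MTT assay, with a stated time of 72 h (on this read-out lower numbers stand for stronger inhibition and higher numbers for weaker inhibition), compound 2 has the lower of the two numbers. Compound 3 `NC1=NC2(CCSCC2)N(OCCCOc2ccc(Cl)cc2)C(N)=N1` is not yet measured. It differs from compound 2 by 4-chlorophenyl in place of 3-bromophenyl on an oxygen on a saturated carbon, with 4-chlorophenyl in place of 3-bromophenyl on an oxygen on a saturated carbon. Among the measured compounds shown here, the one measured step bearing on this is a 7.3-fold lower number from compound 1 to compound 2 (0.87 log units; beyond the scatter), modest and beyond the scatter, where 3-bromophenyl replaced 4-bromophenyl. For the measured compounds named here, no measured pair compares chlorine with bromine. A change of similar size towards a higher number is expected, a 6.7-fold higher number from compound 2 to compound 3 (0.82 log units; beyond the scatter). Compound 3 is estimated at 400 nM, with an expected range of 150 nM to 1000 nM.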

Compound 3, half-maximal inhibitory concentration: 350 nM
Compound 3: the middle estimate sits 1.1-fold (0.06 log units) above what was measured; the measured number falls inside the stated range.
By their numbers in this assay, from the lowest: compound 2; then compounds 3 and 1 (each within the scatter of the next).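

Chloro in place of bromo on an aromatic carbon gives a 1.3-fold lower number from compound 1 to compound 3 (0.10 log units; within the scatter) in this assay, so the two halogens are not separated here when the comparison is between 4-bromophenyl and 4-chlorophenyl. Moving from 3-bromophenyl to 4-chlorophenyl gives a 5.8-fold higher number from compound 2 to compound 3 (0.77 log units; beyond the scatter), which leaves compound 2 apart from both other compounds. No measurement offered here explains these differences.

From the compounds shown here alone, whether 3-chlorophenyl would match 3-bromophenyl remains open. So does the response to a methoxy group or an amine on the phenyl ring, or to a longer chain between the two oxygens.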